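A few compounds are considered here, and "the series" means these few. Any claim that something is new, unique, unknown or untested is made for them only; others in the source may bear on it.

Of the compounds shown here, two that share a core have been tested in an ADME assay on NL20 cells (Homo sapiens) for antiproliferative activity, read by MTT assay, with a stated time of 24 h; on this read-out lower numbers stand for stronger inhibition and higher numbers for weaker inhibition. Compound 1 is `COc1ccc(C(=O)NNC(=O)/C=C/c2ccc(O)cc2)cc1`. In this assay compound 1 gives > 10000 nM, which is a limit of the assay rather than a measured number. Compound 2 is `O=C(/C=C/c1ccc(O)cc1)NNC(=O)c1ccc(O)cc1`, and in this assay compound 2 gives 8620 nM. The step of an at least 1.1-fold lower number from compound 1 to compound 2 (0.06 log units; that floor lies within the scatter) cannot be sized more closely because of the limit of > 10000 nM in this assay, at which 1 of the 2 values shown sits. Compound 3, `COc1ccc(C(=O)NNC(=O)/C=C/c2ccc(O)c(OC)c2)cc1`, departs from compound 1 by a different change: methoxy in place of hydrogen on an aromatic carbon. Going by the values given here, no measured step covers this kind of change; the only measured step concerns hydrogen in place of methyl on an oxygen on an aromatic ring, and it fell within the scatter. Compound 1 already stands at the limit of this assay, so compound 3 is expected to remain a weak inhibitor, with a step that the limit leaves unreadable from compound 1 to compound 3 that is expected to stay within the scatter, and a fair chance that only a limit is reported again. Compound 3 is therefore estimated at 12000 nM, with a range from 5000 nM to 30000 nM.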

Compound 3, half-maximal inhibitory concentration: > 10000 nM
Compound 3 gave a limit, no number (the forecaster's own chance of this, stated with the estimate: 65%); the middle value lies beyond the limit too.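

Compound 1 and compound 3 both stop at a limit in this assay, so no new step can be read between them: the limit of > 10000 nM in this assay, at which 2 of the 3 values shown sit.

The compounds shown leave open whether methoxy in place of hydrogen on an aromatic carbon changes the inhibition at all, and if it does, in which direction and by how much.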